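This account rests on a few compounds, and the source may have more. Where it says the series, first, only, none or still open, it means among the compounds named here.

Measured so far in a functional assay on HeLa cells (Homo sapiens) for antiproliferative activity, read by MTT assay, with a stated time of 48 h; a higher number here means a weaker inhibitor, a lower number a stronger inhibitor:
- compound 1, `COc1ccc(-c2cn3cc(C4=CCN(C(=O)c5cccc(C(F)(F)F)c5)CC4)ccc3n2)cc1OC`: 4860 nM
- compound 2, `COc1ccc(-c2cn3cc(C4=CCN(C(=O)c5ccccc5C(F)(F)F)CC4)ccc3n2)cc1OC`: 7950 nM
- compound 3, `COc1ccc(-c2cn3cc(C4=CCN(S(=O)(=O)c5ccccc5)CC4)ccc3n2)cc1OC`: 12600 nM

Compound 3 gives the highest of the three numbers in this assay. Its nearest neighbour is compound 2: the step of a 1.6-fold higher number from compound 2 to compound 3 (0.20 log units; within the scatter) lies within the scatter, so the two cannot be told apart. Its furthest neighbour is compound 1: the step of a 2.6-fold higher number from compound 1 to compound 3 (0.41 log units; beyond the scatter) is a modest shift beyond the scatter toward weaker inhibition. The remaining step, a 1.6-fold higher number from compound 1 to compound 2 (0.21 log units; within the scatter), is also within the scatter.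

Compound 4, `COc1ccc(-c2cn3cc(C4=CCN(S(=O)(=O)C5CCCC5)CC4)ccc3n2)cc1OC`, is not yet measured. It differs from compound 3 in one place: cyclopentyl in place of phenyl on a sulfonyl sulfur. None of the three measured steps touches this position; each of them concerns either the group on the carbonyl carbon or the exchange of a carbonyl for a sulfonyl on the ring nitrogen. Among the compounds with values here, the only thing the measured numbers show is that changes at this side of the shared core have moved this assay by modest amounts at most. On that basis, the step of a 1.1-fold higher number from compound 3 to compound 4 (0.05 log units; within the scatter) is expected to be small, most likely within the scatter, with no direction that can be argued from the data.

Compound 4 is therefore estimated at 14000 nM in this assay, within a range from 5000 nM to 40000 nM.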

Compound 4, half-maximal inhibitory concentration: 6470 nM
Compound 4: the middle estimate sits 2.2-fold (0.34 log units) above what was measured, within the range that was stated.
By their numbers in this assay, from the lowest: compounds 1, 4, 2 and 3 (each within the scatter of the next, the first and the last beyond it).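

In this assay, within the data shown here, this is the first step that changes the group on the sulfonyl sulfur itself: a non-aromatic cyclopentyl ring takes the place of the aromatic phenyl ring (with a 1.9-fold lower number from compound 3 to compound 4 (0.29 log units; within the scatter)). That step lies within the scatter, so these two compounds cannot be told apart, and an aromatic ring on this sulfur is not shown to matter here. Compound 4 also cannot be told apart from either carbonyl compound (with a 1.2-fold lower number from compound 2 to compound 4 (0.09 log units; within the scatter) and a 1.3-fold higher number from compound 1 to compound 4 (0.12 log units; within the scatter)), so the modest gap between compound 1 and compound 3 does not hold for every sulfonyl compound, and compound 3 is the one that goes against an even picture. No measurement is available that could explain these results.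

Going by these compounds, what remains open is whether anything placed on this sulfur can move the number beyond the scatter, such as a small methyl group, or an amine or a carboxylic acid at the end of a longer chain. On these data alone, it is also open whether the trifluoromethyl group that compound 1 carries on its phenyl ring would change the result if placed on the phenyl ring of compound 3.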